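Cytotoxicity of long-chain ureas and amides on the tricarboxylate core

The compounds below may be only part of what the source reports. "The series", "measured", "known", "first", "only" and "open" are said of these compounds alone.

Of the compounds shown here, three sharing one acidic core have been tested in an ADME assay on cells (Epithelial cell, Homo sapiens) for cytotoxicity, read by MTT assay; on this read-out higher numbers stand for an effect only at larger amounts of compound and lower numbers for an effect already at smaller amounts. Compound 1, `CCCCCCCCCCCCCCCCCCCCNC(=O)NC(CCC(=O)O)(CCC(=O)O)CCC(=O)O`, gives 210000 nM. Compound 2, `CCCCCCCCCCCCCCCCCCCC(=O)NC(CCC(=O)O)(CCC(=O)O)CCC(=O)O`, gives 340000 nM. Compound 3, `CCCCCCCCCCCCCCCCCCCCCC(=O)NC(CCC(=O)O)(CCC(=O)O)CCC(=O)O`, gives 250000 nM. The three numbers lie within the usual scatter of one another, so no order among them can be read. The difference between the core of compound 1 and the core of compound 3 is not broken down here.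

Compound 4, `CCCCCCCCCCCCCCCCCCNC(=O)NC(CCC(=O)O)(CCC(=O)O)CCC(=O)O`, has not yet been measured. It differs from compound 1 by hydrogen in place of ethyl on a saturated chain carbon, ten or more bonds along the chain from an amide-type nitrogen. The same kind of change appears between two measured compounds: compound 2 differs from compound 3 by hydrogen in place of ethyl on a saturated chain carbon, ten or more bonds along the chain from a carbonyl carbon, and that step gave a 1.4-fold higher number from compound 3 to compound 2 (0.13 log units; within the scatter). Around the place the two changes differ only in what lies at the far end of the chain, an amide-type nitrogen in one case and a carbonyl carbon in the other.

Resting on that step, compound 4 is expected to give 250000 nM in this assay, between 120000 nM and 500000 nM, which means an expected step of a 1.2-fold higher number from compound 1 to compound 4 (0.08 log units; within the scatter).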

Compound 4, half-maximal effective concentration: 280000 nM
Compound 4: the middle estimate sits 1.1-fold (0.05 log units) below what was measured; the measured number falls inside the stated range.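

In this assay, the change from ethyl to hydrogen on a saturated chain carbon gives a 1.3-fold higher number from compound 1 to compound 4 (0.12 log units; within the scatter) on the core of compound 1. Read beside the same change on the core of compound 3, the two results agree: the same change on two cores in this assay, a 1.4-fold higher number (0.13 log units; within the scatter) from compound 3 to compound 2 and a 1.3-fold higher number (0.12 log units; within the scatter) from compound 1 to compound 4, 1.0-fold (0.01 log units) apart, within the scatter of two such steps. This shows that, for these two cores, the change carries over with no detectable difference, but each step is itself within the scatter, so the agreement is between two results too small to read as real effects, and it does not show that a clear effect of the change would transfer from one core to the other.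

The compounds shown leave open what happens with a much shorter chain, or with an amine or a phenyl ring on the chain. They also leave open whether the match would hold on a core carrying esters in place of the carboxylic acids.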